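This account rests on a few compounds, and the source may have more. Where it says the series, first, only, none or still open, it means among the compounds named here.

Measured in an ADME assay on L02 cells (Homo sapiens) for cytotoxicity, read by MTT assay; on this read-out lower numbers stand for stronger inhibition and higher numbers for weaker inhibition:
- Compound 1 `COc1ccc(/C=C/C(=O)c2ccc(OC)c3c2OC(C)(C)C=C3)cc1OCC=C(C)C`: > 10000 nM
- Compound 2 `COc1ccc(/C=C/C(=O)c2ccc(OC)c3c2OC(C)(C)C=C3)cc1OCCO`: > 10000 nM
- Compound 3 `CCCCC(=O)Oc1cc(/C=C/C(=O)c2ccc(OC)c3c2OC(C)(C)C=C3)ccc1OC`: > 10000 nM

Each of these entries is a limit of the assay and not a number. The set as a whole therefore offers only (the limit of > 10000 nM in this assay, at which 3 of the 3 values shown sit).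

Compound 3 stands at > 10000 nM, which is a limit. Among the compounds with values here, its true position in this assay remains unknown, and no measured compound gives a number to compare it with.

Compound 4 `C=CC(=O)Oc1cc(/C=C/C(=O)c2ccc(OC)c3c2OC(C)(C)C=C3)ccc1OC` keeps the shared core and the ester link of compound 3, but carries vinyl in place of butyl on a carbonyl carbon. The same difference reads butylcarbonyl to vinylcarbonyl.

Two measured steps changed the group on this oxygen on an aromatic ring: a step that the two limits leave unreadable from compound 1 to compound 3, and a step that the two limits leave unreadable from compound 2 to compound 3. Neither gives a size or a direction, so they provide no basis for expecting a change beyond the scatter in this assay. Compound 4 is expected to stay in the same region and may well report only a limit again.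

The estimated step is a step that the limit leaves unreadable from compound 3 to compound 4.

For compound 4, the expected value is 12000 nM, with an estimated range from 5000 nM to 30000 nM.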

Compound 4, half-maximal inhibitory concentration: > 10000 nM
Compound 4 was reported as a limit; the forecaster's own chance of this, stated with the estimate: 70%; the middle value lies beyond the limit too.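

In this assay compound 4 gives > 10000 nM, which is a limit and not a number. No step linking compound 4 with compound 1, compound 2 or compound 3 can be read, and the set shows only a shared limit: the limit of > 10000 nM in this assay, at which 4 of the 4 values shown sit.

The compounds shown leave open how far each lies beyond that limit and whether changing the group on this oxygen alters the read-out at all.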